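The compounds below may be only part of what the source reports. "The series", "measured", "known", "first", "only" and "open" are said of these compounds alone.

Measured so far in a functional assay on the whole organism for antagonist activity, with Mus musculus as the target; on this read-out lower numbers stand for an effect already at smaller amounts and higher numbers for an effect only at larger amounts of compound:
- compound 1 `CC(=O)N(C)CC#CCn1ccnc1` gives > 100 mg/kg as a limit of the assay, not a number
- compound 2 `CCOC(=O)N(C)CC#CCn1ccnc1` gives 97 mg/kg as a number
- compound 3 `CN(C)C(=O)N(C)CC#CCN1CCCC1` gives 6.6 mg/kg as a number

Of the two values that are not limits, compound 3 holds the lower (6.6 mg/kg), and the gap to compound 2 lies beyond the scatter. Compound 4 `CN(C)C(=O)N(C)CC#CCn1ccnc1` matches compound 3 except for one exchange: 1H-imidazol-1-yl in place of pyrrolidin-1-yl on a saturated chain carbon bound to a triple-bonded carbon. Among the measured compounds shown here, no measured step makes this exchange. For the measured compounds named here, the only measured step (an at least 1.0-fold lower number from compound 1 to compound 2 (0.01 log units; that floor lies within the scatter)) puts ethoxy in place of methyl on a carbonyl carbon, and its floor lies within the scatter. The nearest guide is compound 2, which also carries 1H-imidazol-1-yl and gives 97 mg/kg in this assay despite a different group on its carbonyl carbon. A large move to a higher number is therefore expected, estimated as an 11-fold higher number from compound 3 to compound 4 (1.03 log units; beyond the scatter) in this assay here. Compound 4 is estimated at 70 mg/kg with 20 mg/kg to 200 mg/kg as the expected range.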

Compound 4, dose for half-maximal effect: 11.8 mg/kg
For compound 4 the middle estimate is 5.9-fold (0.77 log units) above the measured one; the measured number lies below the stated range.
By their numbers in this assay, from the lowest: compounds 3 and 4 (each within the scatter of the next); then compound 2. At a limit, above all of these: compound 1.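

In this assay, 1H-imidazol-1-yl in place of pyrrolidin-1-yl on a saturated chain carbon bound to a triple-bonded carbon gives a 1.8-fold higher number from compound 3 to compound 4 (0.25 log units; within the scatter), so with dimethylamino on the carbonyl carbon, these two rings cannot be told apart at this position. With 1H-imidazol-1-yl held fixed, the group on the carbonyl carbon does make a difference: dimethylamino in place of ethoxy gives an 8.2-fold lower number from compound 2 to compound 4 (0.91 log units; beyond the scatter), and dimethylamino in place of methyl gives an at least 8.4-fold lower number from compound 1 to compound 4 (0.92 log units; beyond the scatter). Compound 1 gives a limit of the assay rather than a number, so its step is only a floor: the limit of > 100 mg/kg in this assay, at which 1 of the 4 values shown sits.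

Pyrrolidin-1-yl appears here only with dimethylamino on the carbonyl carbon, so its behaviour with ethoxy or methyl there remains open. Also open, on these data alone, is how piperidine or an open-chain diethylamino group would compare with these two rings at this position.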